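The source may report more compounds than this note shows. Statements on the series, on what has been measured and on what is new or still open speak of the compounds shown alone.

Among the measured compounds shown here, compound 2 `CC1=C(C(=O)OC2CCC2)C(c2ccoc2)NC(=O)N1` gives the lowest of the two numbers so far: in an assay on membranes from HEK293 cells for displacement of a labelled ligand from adenosine receptor A2b (Homo sapiens), read by scintillation counting, with a stated time of 30 min (a lower number here means a stronger inhibitor, a higher number a weaker inhibitor), compound 2 gives 307 nM, and the thioester compound 1 `CC1=C(C(=O)SC(C)C)C(c2ccoc2)NC(=O)N1` gives 637 nM, a step of a 2.1-fold lower number from compound 1 to compound 2 (0.32 log units; beyond the scatter). Compound 3 `CC1=C(C(=O)OCC2CCC2)C(c2ccoc2)NC(=O)N1` differs from compound 2 by cyclobutylmethyl in place of cyclobutyl on an oxygen next to a carbonyl group. No measured step homologates the alkyl on the ester oxygen, so the one shown step does not bear on this change. Compound 3 is therefore expected to land within the scatter of compound 2, with an estimated step of a 1.0-fold lower number from compound 2 to compound 3 (0.01 log units; within the scatter), giving an expected 300 nM for compound 3, in a range from 120 nM to 750 nM.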

Compound 3, inhibition constant: 739 nM
Compound 3: the middle estimate sits 2.5-fold (0.39 log units) below what was measured, within the range that was stated.
By their numbers in this assay, from the lowest: compound 2; then compounds 1 and 3 (each within the scatter of the next).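

On an oxygen next to a carbonyl group, the change from cyclobutyl to cyclobutylmethyl is not silent: it gives a 2.4-fold higher number from compound 2 to compound 3 (0.38 log units; beyond the scatter) in this assay. The cyclobutylmethoxy ester and the isopropylsulfanyl thioester give a 1.2-fold higher number from compound 1 to compound 3 (0.06 log units; within the scatter), so the gain seen with cyclobutyloxy does not carry over to cyclobutylmethoxy. No measurement available here accounts for the step.

Open, going by these compounds, is whether cyclopentyl or a longer chain such as n-butyl on that oxygen follows the same direction, and whether an amide in place of the ester keeps the cyclobutyl preference.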